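Swapping a fluorinated phenyl for a methylpyridine on the amide nitrogen

This account rests on a few compounds, and the source may have more. Where it says the series, first, only, none or still open, it means among the compounds named here.

Measured so far:
Compound 1, `Cc1ccc(F)cc1N(C)C(=O)c1ccc(-c2ccc(O)cc2)o1`: 2200 nM
Compound 2, `Cc1c(F)cccc1N(C)C(=O)c1ccc(-c2ccc(O)cc2)o1`: 3900 nM

Both compounds were tested in an assay on cytosol from placenta for inhibition of 17-beta-hydroxysteroid dehydrogenase type 2 (Homo sapiens), read by HPLC, using microsomes, with a stated time of 10 min, in the presence of a further agent that is not named here; a lower number here means a stronger inhibitor, a higher number a weaker inhibitor. For the measured compounds named here, compound 2 gives 3900 nM, and the only other number, from compound 1, lies within the scatter of it: a 1.8-fold higher number from compound 1 to compound 2 (0.25 log units; within the scatter). Compound 3, `Cc1ccncc1N(C)C(=O)c1ccc(-c2ccc(O)cc2)o1`, differs from compound 2 by 4-methylpyridin-3-yl in place of 3-fluoro-2-methylphenyl on an amide-type nitrogen. Going by the values given here, no measured step swaps a carbon ring for one with a hetero atom, so nothing here predicts the size or direction of this change. Compound 3 is therefore estimated near compound 2, at 5000 nM (range 1500 nM to 16000 nM), an expected step of a 1.3-fold higher number from compound 2 to compound 3 (0.11 log units; within the scatter).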

Compound 3, half-maximal inhibitory concentration: > 20000 nM
Compound 3 ended at the assay's limit; the forecaster's own chance of this, stated with the estimate: 10%; at least 4.0-fold (0.60 log units) between middle value and limit.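

Compound 3 gives > 20000 nM in this assay, which is a limit of the assay and not a number: the limit of > 20000 nM in this assay, at which 1 of the 3 values shown sits.

The two fluorinated rings lie within the scatter of each other, but 4-methylpyridin-3-yl on this amide-type nitrogen brings an at least 5.1-fold higher number from compound 2 to compound 3 (0.70 log units; beyond the scatter) and an at least 9.0-fold higher number from compound 1 to compound 3 (0.95 log units; beyond the scatter). This position therefore does respond to the ring placed on it, and this change weakens inhibition beyond the scatter.

Going by these compounds, how far compound 3 lies past the limit stays open. These data do not show what produces the loss of inhibition. Also open, on these data alone, is whether a pyridine ring carrying a methoxy group or an amine would restore inhibition.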